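Chloro in Place of Hydrogen on the Aryl Amide of Compound 3

The compounds below may be only part of what the source reports. "The series", "measured", "known", "first", "only" and "open" are said of these compounds alone.

In a functional assay on HeLa cells (Homo sapiens) for inhibition, read by CCK-8 assay, with a stated time of 72 h (a lower number here means a stronger inhibitor, a higher number a weaker inhibitor), compound 1 `O=C(NO)c1ccc(CNC(=O)c2n[nH]cc2NC(=O)c2ccccc2Cl)cc1` gives 16200 nM. Compound 2 `Nc1ccccc1NC(=O)c1ccc(CNC(=O)c2n[nH]cc2NC(=O)c2ccccc2F)cc1` gives 3440 nM, and compound 3 `Nc1ccccc1NC(=O)c1ccc(CNC(=O)c2n[nH]cc2NC(=O)c2ccccc2)cc1` gives 4060 nM. Compound 3 thus stands second highest of the three numbers, close to compound 2 and well apart from compound 1. For the measured compounds named here, the only measured single-point step, a 1.2-fold higher number from compound 2 to compound 3 (0.07 log units; within the scatter), lies within the scatter. Compound 4 `Nc1ccccc1NC(=O)c1ccc(CNC(=O)c2n[nH]cc2NC(=O)c2ccccc2Cl)cc1` differs from compound 3 by chloro in place of hydrogen on an aromatic carbon. Going by the values given here, that fluoro step bears most directly on this change; compound 1 carries the chloro but differs elsewhere as well, so its value alone fixes no step. Compound 4 is therefore expected to change little, a 1.2-fold lower number from compound 3 to compound 4 (0.06 log units; within the scatter), with an estimate of 3500 nM and a range from 1500 nM to 8000 nM.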

Compound 4, half-maximal inhibitory concentration: 10500 nM
Compound 4: middle estimate off by 3.0-fold (0.48 log units), on the low side, and the stated range ends below it.
By their numbers in this assay, from the lowest: compounds 2 and 3 (each within the scatter of the next); then compounds 4 and 1 (each within the scatter of the next).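

In this assay chloro on this aromatic carbon is not a silent change: the step is modest but beyond the scatter (a 2.6-fold higher number from compound 3 to compound 4 (0.41 log units; beyond the scatter)), unlike the exchange of fluoro for hydrogen (a 1.2-fold higher number from compound 2 to compound 3 (0.07 log units; within the scatter)). The two halogens also separate here (a 3.1-fold higher number from compound 2 to compound 4 (0.48 log units; beyond the scatter)). With chloro held in place, 2-aminophenyl in place of hydroxy on the amide-type nitrogen stays within the scatter (a 1.5-fold lower number from compound 1 to compound 4 (0.19 log units; within the scatter)).

No measurement at hand explains why chloro parts from fluoro and hydrogen. On these data alone, how a bromo, methyl or methoxy group would behave on this same aromatic carbon remains open.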